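Bromo for trifluoromethyl on a fluorinated core

The source may report more compounds than this note shows. Statements on the series, on what has been measured and on what is new or still open speak of the compounds shown alone.

Working notes on a small series sharing a common core. Compound 1 `O=C(Nc1ccc(Oc2ccnc3[nH]ccc23)cc1)c1cc(-c2ccc(C(F)(F)F)cc2)ncn1` gives 6240 nM in a functional assay on MCF7 cells (Homo sapiens) for cytotoxicity, read by MTT assay, with a stated time of 72 h; a higher number here means a weaker inhibitor, a lower number a stronger inhibitor. Compound 2 `O=C(Nc1ccc(Oc2ccnc3[nH]ccc23)cc1)c1cc(-c2ccc(Br)cc2)ncn1` carries the change bromo in place of trifluoromethyl on an aromatic carbon and gives 3840 nM in this assay; the step is a 1.6-fold lower number from compound 1 to compound 2 (0.21 log units; within the scatter). Compound 3 `O=C(Nc1ccc(Oc2ccnc3[nH]ccc23)c(F)c1)c1cc(-c2ccc(C(F)(F)F)cc2)ncn1` differs from compound 1 by fluoro in place of hydrogen on an aromatic carbon. In this assay compound 3 gives 2840 nM; the step is a 2.2-fold lower number from compound 1 to compound 3 (0.34 log units; beyond the scatter). Compound 3 holds the lowest number of the three measured, yet its gap to compound 2 lies within the scatter, so no ranking between these two is claimed.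

Compound 4 `O=C(Nc1ccc(Oc2ccnc3[nH]ccc23)c(F)c1)c1cc(-c2ccc(Br)cc2)ncn1` has not been measured. It differs from compound 3 by bromo in place of trifluoromethyl on an aromatic carbon. Among the measured compounds shown here, this is the same change as the one from compound 1 to compound 2, made on the core of compound 3 rather than that of compound 1; the two cores differ by the change noted above. For the measured compounds named here, the only guide is the step of a 1.6-fold lower number from compound 1 to compound 2 (0.21 log units; within the scatter), which stayed within the scatter. Going by the values given here, compound 4 is therefore expected to move by about a 1.6-fold lower number from compound 3 to compound 4 (0.20 log units; within the scatter) from compound 3, resting on compound 1 to compound 2 as the single earlier instance. Compound 4 is estimated at 1800 nM in this assay, expected between 900 nM and 3600 nM.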

Compound 4, half-maximal inhibitory concentration: 10300 nM
Compound 4: middle estimate off by 5.7-fold (0.76 log units), on the low side, and the stated range ends below it.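

In this assay, bromo in place of trifluoromethyl gives a 3.6-fold higher number from compound 3 to compound 4 (0.56 log units; beyond the scatter) on the core of compound 3, and this does not match the earlier step on the core of compound 1: the same change on two cores in this assay, a 1.6-fold lower number (0.21 log units; within the scatter) from compound 1 to compound 2 and a 3.6-fold higher number (0.56 log units; beyond the scatter) from compound 3 to compound 4, 5.9-fold (0.77 log units) apart, beyond the scatter of two such steps

Read along the other edge, fluoro in place of hydrogen gives a 2.7-fold higher number from compound 2 to compound 4 (0.43 log units; beyond the scatter) with bromo on the outer phenyl ring, which does not match its step with trifluoromethyl there: the same change on two cores in this assay, a 2.2-fold lower number (0.34 log units; beyond the scatter) from compound 1 to compound 3 and a 2.7-fold higher number (0.43 log units; beyond the scatter) from compound 2 to compound 4, 5.9-fold (0.77 log units) apart, beyond the scatter of two such steps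

The two changes therefore do not add in these four compounds, and the step measured on one core was no guide to the step on the other, but this single set of four shows neither the reason for the mismatch nor whether it extends beyond them.

The compounds shown leave open whether the same reversal appears when a group such as chloro, methyl or nitrile stands in place of trifluoromethyl. They also leave open whether it holds on a core carrying chloro in place of the added fluoro.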